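Naphthyloxy-acetohydrazones: cytotoxicity in HEL cells

A few compounds are considered here, and "the series" means these few. Any claim that something is new, unique, unknown or untested is made for them only; others in the source may bear on it.

Measured so far:
compound 1, `O=C(COc1cccc2ccccc12)N/N=C/c1ccc(O)cc1`: 20 ug/mL
compound 2, `O=C(COc1cccc2ccccc12)N/N=C/c1cccc(O)c1`: 100 ug/mL
compound 3, `COc1ccc(/C=N/NC(=O)COc2cccc3ccccc23)cc1O`: 100 ug/mL

In an ADME assay on HEL cells (Homo sapiens) for cytotoxicity (a lower number here means that less compound is tolerated, a higher number that more compound is tolerated), compound 2 gives 100 ug/mL, level with compound 3 at the digits shown, and together they sit at the highest number of the three; its furthest neighbour is compound 1, with a 5.0-fold higher number from compound 1 to compound 2 (0.70 log units; beyond the scatter). Adding a methoxy group brought no change at the digits printed from compound 2 to compound 3 (within the scatter).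

Compound 4, `O=C(COc1cccc2ccccc12)N/N=C/C=C/c1ccccc1`, has not yet been tested. It differs from compound 2 in one place: 2-phenylethenyl in place of 3-hydroxyphenyl on a carbon with a double bond to nitrogen. Neither measured step matches this change. The step from compound 1 to compound 2 moved the hydroxyl without removing it, and the step to compound 3 only added a group; here the hydroxyl leaves altogether and a 2-phenylethenyl group enters. The two known steps ranged from none to modest, so a step of about that size in either direction, or none beyond the scatter, is plausible for this assay.

Compound 4 is therefore expected to give about 100 ug/mL, between 20 ug/mL and 200 ug/mL, which would mean an estimated no change at the digits printed from compound 2 to compound 4 (within the scatter).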

Compound 4, minimum cytotoxic concentration: 100 ug/mL
Estimate against measurement, compound 4: no gap at the digits printed, within the range that was stated.
By their numbers in this assay, from the lowest: compound 1; then compounds 2, 3 and 4 (each within the scatter of the next).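

In this assay, the hydroxyl-bearing ring on the carbon with a double bond to nitrogen can give way to a group with no hydrogen-bond donor or acceptor, and the number holds (no change at the digits printed from compound 2 to compound 4 (within the scatter)). The same group also stands clear of the 4-hydroxyphenyl compound (a 5.0-fold higher number from compound 1 to compound 4 (0.70 log units; beyond the scatter)), so among these four compounds, the low number appears only with 4-hydroxyphenyl, while compounds 2, 3 and 4 stay within the scatter of one another. No measurement shown here gives a reason for either step.

As far as these compounds go, it remains open whether the double bond of 2-phenylethenyl matters, which a 2-phenylethyl group could test. From the compounds shown here alone, it is also open whether a group with an amine or a carboxylic acid at this place would keep the number or move it.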